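Chain extension from compound 3 to compound 4

The compounds below may be only part of what the source reports. "The series", "measured", "known", "first", "only" and "open" are said of these compounds alone.

Values in a functional assay on HeLa cells (Homo sapiens) for inhibition, read by MTT assay, with a stated time of 48 h; on this read-out higher numbers stand for weaker inhibition and lower numbers for stronger inhibition:
- compound 1 `O=C(CCCCOC(=O)c1ccc2c(c1)no[n+]2[O-])NO`: 15900 nM
- compound 2 `O=C(CCCCCOC(=O)c1ccc2c(c1)no[n+]2[O-])NO`: 17300 nM
- compound 3 `O=C(CCCCCCOC(=O)c1ccc2c(c1)no[n+]2[O-])NO`: 9180 nM

Compound 3, at 9180 nM, lies within the scatter of both compound 1 and compound 2, so the three values do not separate.

Next in the series is compound 4 `O=C(CCCCCCCOC(=O)c1ccc2c(c1)no[n+]2[O-])NO`, not yet measured. The change is (hydroxycarbamoyl)methyl in place of hydroxycarbamoyl on a saturated chain carbon, six bonds along the chain from an oxygen next to a carbonyl group.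

The same kind of replacement gave a 1.1-fold higher number from compound 1 to compound 2 (0.04 log units; within the scatter) and a 1.9-fold lower number from compound 2 to compound 3 (0.28 log units; within the scatter). Taken twice over, it gave a 1.7-fold lower number from compound 1 to compound 3 (0.24 log units; within the scatter). All three steps lie within the scatter, and no trend can be read from them.

No step beyond the scatter is therefore expected in this assay. The expected step is a 1.2-fold higher number from compound 3 to compound 4 (0.08 log units; within the scatter). For compound 4 the estimated value is 11000 nM, with an expected range of 5500 nM to 22000 nM.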

Compound 4, half-maximal inhibitory concentration: 5310 nM
Beside the measured number, compound 4's estimate is 2.1-fold (0.32 log units) above it; the whole stated range lies above it.
By their numbers in this assay, from the lowest: compounds 4, 3, 1 and 2 (each within the scatter of the next, the first and the last beyond it).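

In this assay, a 1.7-fold lower number from compound 3 to compound 4 (0.24 log units; within the scatter), so a single added chain carbon still does not separate neighbouring compounds, but the longest chain shown now stands apart from the two shortest, with a 3.3-fold lower number from compound 2 to compound 4 (0.51 log units; beyond the scatter) and a 3.0-fold lower number from compound 1 to compound 4 (0.48 log units; beyond the scatter), the first steps in the series beyond the scatter. Compound 2 keeps this from being a steady fall with each added carbon, and the one-carbon extension does not differ measurably between the two places where it can be compared: the same change on two cores in this assay, a 1.1-fold higher number (0.04 log units; within the scatter) from compound 1 to compound 2 and a 1.7-fold lower number (0.24 log units; within the scatter) from compound 3 to compound 4, 1.9-fold (0.27 log units) apart, within the scatter of two such steps. The two-carbon extension also gives no firm difference between its two starting points, although only its step from compound 2 lies beyond the scatter: the same change on two cores in this assay, a 1.7-fold lower number (0.24 log units; within the scatter) from compound 1 to compound 3 and a 3.3-fold lower number (0.51 log units; beyond the scatter) from compound 2 to compound 4, 1.9-fold (0.27 log units) apart, within the scatter of two such steps.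

The compounds shown leave open whether a longer chain would continue this direction or reverse it. They also leave open whether a carboxylic acid in place of the hydroxycarbamoyl end would keep any of the gain.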